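This account rests on a few compounds, and the source may have more. Where it says the series, first, only, none or still open, it means among the compounds named here.

Measured so far:
compound 1 `N#Cc1cnc(NCc2cnccc2C(F)(F)F)cc1N[C@H]1CC[C@H](O)CC1` — 6500 nM
compound 2 `CC1(C)C[C@H](Nc2cc(NCc3cnccc3C(F)(F)F)ncc2C#N)CC(C)(C)[C@@H]1O` — 700 nM

Both were tested in an assay on isolated protein for inhibition of protein kinase C delta type (Homo sapiens), read by TR-FRET, with a stated time of 2 h; a higher number here means a weaker inhibitor, a lower number a stronger inhibitor. Compound 1 stands at the higher of the two numbers, so it is the weaker inhibitor here; compound 2 gives 700 nM, and the gap between the two lies beyond the usual scatter of repeated measurements.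

Compound 3 `CC1(C)[C@@H](Nc2cc(NCc3cnccc3C(F)(F)F)ncc2C#N)C[C@H]1C(N)=O` has not been measured. It differs from compound 1 in a single place: 3-carbamoyl-2,2-dimethylcyclobutyl in place of 4-hydroxycyclohexyl on a nitrogen on an aromatic ring. The shared core is untouched; only the ring attached to that nitrogen changes, and a carbamoyl replaces the hydroxyl as the polar group on it.

Within the data shown here, no step between two measured compounds isolates this change, so the expectation rests on the two values alone. Since compound 2 gives 700 nM with a more substituted ring on the same nitrogen, compound 3 is expected to give a somewhat lower number than compound 1, a step of a 2.6-fold lower number from compound 1 to compound 3 (0.41 log units; beyond the scatter) of modest size, not much beyond the scatter. Compound 3 is estimated at 2500 nM, within a range of 600 nM to 9000 nM.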

Compound 3, half-maximal inhibitory concentration: 4500 nM
The estimate for compound 3 lay 1.8-fold (0.26 log units) below the measured number; measured number inside the range.
By their numbers in this assay, from the lowest: compound 2; then compounds 3 and 1 (each within the scatter of the next).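

In this assay, replacing 4-hydroxycyclohexyl with 3-carbamoyl-2,2-dimethylcyclobutyl on this nitrogen gives a 1.4-fold lower number from compound 1 to compound 3 (0.16 log units; within the scatter) and leaves compound 1 and compound 3 indistinguishable. This position therefore accepts a four-membered ring carrying a carbamoyl in place of a six-membered ring carrying a hydroxyl, with no difference that can be read in this measurement. Nothing available explains why these two groups give such similar results.

On these data alone, the ring, its two methyl groups and the carbamoyl all differ in this one step, so the contribution of each remains unknown. A cyclobutyl ring bearing an amine or a carboxylic acid in place of the carbamoyl, or a cyclohexyl ring bearing a carbamoyl, would begin to separate these parts.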